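The source may report more compounds than this note shows. Statements on the series, on what has been measured and on what is new or still open speak of the compounds shown alone.

Working notes on the series in an assay on HEK293 cells for binding affinity to prostaglandin E2 receptor EP2 subtype (Rattus norvegicus); on this read-out lower numbers stand for stronger inhibition and higher numbers for weaker inhibition.

Compound 1 `O=C(O)CCCCCCN1C(=O)CC[C@@H]1CC[C@@H](O)CCc1ccccc1` carries an open-chain acid on the core. In this assay compound 1 returns only a limit of the assay, > 3200 nM, and no number. Compound 2 `O=C(O)c1ccc(CCCN2C(=O)CCC2CCC(O)Cc2ccc(F)cc2)cc1` carries a benzoic acid side and a 4-fluorophenyl end group. Compound 2 likewise sits at a limit of the assay in this assay, > 3200 nM, so no number is known for it; it stands at the limit of > 3200 nM in this assay, at which 2 of the 3 values shown sit. For the measured compounds named here, compound 3 `O=C(O)c1ccc(CCCN2C(=O)CC[C@@H]2CCC(O)Cc2ccc(Cl)cc2)s1`, with a thiophene acid and a 4-chlorophenyl end group, is the only member of the three with a measured number, and in this assay compound 3 gives 86 nM.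

Compound 4 `O=C(O)c1ccc(CCCN2C(=O)CCC2CCC(O)Cc2cccc(Cl)c2)cc1` is not yet measured in this assay. It differs from compound 2 by 3-chlorophenyl in place of 4-fluorophenyl on a saturated chain carbon, two bonds along the chain from an oxygen on a saturated carbon. Going by the values given here, no measured step isolates this change, so the size of the effect rests on the values at hand. The value of compound 3 shows that a chlorophenyl end group can go together with a measured number in this assay. Compound 4 is therefore expected to move toward a measurable value, with the step from compound 2 to compound 4 estimated as an at least 2.1-fold lower number from compound 2 to compound 4 (0.32 log units; beyond the scatter). For compound 4 the expected result in this assay is 1500 nM, with a range from 300 nM to 6000 nM.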

Compound 4, half-maximal inhibitory concentration: > 3200 nM
Compound 4: no number, only a limit; the forecaster's own chance of this, stated with the estimate: 40%; middle value at least 2.1-fold (0.32 log units) from the limit.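

Compound 2 and compound 4 both sit at a limit of this assay and not at a number, so no step can be read for 3-chlorophenyl in place of 4-fluorophenyl: the limit of > 3200 nM in this assay, at which 3 of the 4 values shown sit.

The compounds shown leave open whether these two end groups differ at all in this assay, and which structural feature goes with the measured number of compound 3.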